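The compounds below may be only part of what the source reports. "The series", "measured", "known", "first", "only" and "open" are said of these compounds alone.

Measured compounds:
compound 1 `Cc1ccc(C2=NN(c3nc(-c4ccc(Br)cc4)cs3)C(c3ccc(F)cc3)C2)s1` with > 500 ug/mL
compound 2 `Fc1ccc(C2CC(c3ccc(Cl)s3)=NN2c2nc(-c3ccc(Br)cc3)cs2)cc1` with > 500 ug/mL
compound 3 `CS(=O)(=O)c1ccc(-c2csc(N3N=C(c4ccc(Cl)s4)CC3c3ccc(F)cc3)n2)cc1` with > 500 ug/mL

In an ADME assay on NIH3T3 cells (Mus musculus) for cytotoxicity, read by XTT assay, with a stated time of 24 h (a higher number here means a weaker inhibitor, a lower number a stronger inhibitor), compound 1 gives > 500 ug/mL, which is a limit of the assay and not a number. For compound 2 the value > 500 ug/mL is likewise a limit. For compound 3 the value > 500 ug/mL is a limit as well. The change from compound 2 to compound 1, (methyl in place of chloro on an aromatic carbon), gives a step that the two limits leave unreadable from compound 2 to compound 1. Compound 3 differs from compound 2 in its core by methylsulfonyl in place of bromo on an aromatic carbon, and that step is a step that the two limits leave unreadable from compound 2 to compound 3. Neither step can be read because of the limit of > 500 ug/mL in this assay, at which 3 of the 3 values shown sit.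

Compound 4 `Cc1ccc(C2=NN(c3nc(-c4ccc(S(C)(=O)=O)cc4)cs3)C(c3ccc(F)cc3)C2)s1` is not yet measured. It differs from compound 3 by methyl in place of chloro on an aromatic carbon, the same change as from compound 2 to compound 1. Since that earlier step that the two limits leave unreadable from compound 2 to compound 1 could not be read, the step expected from compound 3 to compound 4 in this assay is estimated at a step that the limit leaves unreadable from compound 3 to compound 4, with the result most likely again at the limit. Compound 4 is therefore estimated at 600 ug/mL, expected between 300 ug/mL and 1500 ug/mL.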

Compound 4, half-maximal inhibitory concentration: 374 ug/mL
Compound 4: the middle estimate sits 1.6-fold (0.21 log units) above what was measured, within the range that was stated.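

In this assay, replacing 5-chlorothiophen-2-yl with 5-methylthiophen-2-yl on the core bearing methylsulfonyl gives an at least 1.3-fold lower number from compound 3 to compound 4 (0.12 log units; that floor lies within the scatter). Methylsulfonyl in place of bromo, with the methyl group in place, gives an at least 1.3-fold lower number from compound 1 to compound 4 (0.12 log units; that floor lies within the scatter). Both figures are floors that lie within the scatter, and the same methyl for chloro change from compound 2 to compound 1 cannot be read, so the data show no size for this change on either core and do not show that it carries from one core to the other: the limit of > 500 ug/mL in this assay, at which 3 of the 4 values shown sit.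

The compounds shown leave open how this change would read on a pair with both values clear of the limit. They also leave open what an amine or a carboxylic acid in place of the chloro would give in this assay.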